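The source may hold more compounds than are shown below. What is called first, only, known or untested is meant among the compounds shown, and "the series" means these compounds.

Measured in a functional assay on HeLa cells (Homo sapiens) for inhibition, read by MTT assay, with a stated time of 48 h; on this read-out higher numbers stand for weaker inhibition and lower numbers for stronger inhibition:
Compound 1 `O=C(CC(c1ccc(F)cc1)C(C(=O)Nc1ccccn1)C(=O)Nc1ccccn1)c1ccccc1`: 20800 nM
Compound 2 `O=C(CC(c1cccs1)C(C(=O)Nc1ccccn1)C(=O)Nc1ccccn1)c1ccccc1`: "not active" (no number reported)

Compound 2 has no place on the numerical scale, since compound 2 is reported only as "not active" (no number reported). Among the measured compounds shown here, the sole figure comes from compound 1, at 20800 nM. Compound 3 (`O=C(CC(c1ccc([N+](=O)[O-])cc1)C(C(=O)Nc1ccccn1)C(=O)Nc1ccccn1)c1ccccc1`) has yet to be measured. The change 4-nitrophenyl in place of thiophen-2-yl on a saturated chain carbon bound to two saturated chain carbons puts 4-nitrophenyl in place of thiophen-2-yl on a saturated chain carbon bound to two saturated chain carbons. Compound 1 also carries a six-membered aromatic ring of carbon only at that place, so compound 3 is expected to read closer to compound 1 at 20800 nM than to the result without a number. In this assay, the expected step is therefore towards measurable but weak inhibition, with no gap from compound 1 beyond the scatter. A further result without a number remains possible. Compound 3 is estimated at 25000 nM, with an expected range of 8000 nM to 80000 nM.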

Compound 3, half-maximal inhibitory concentration: 30000 nM
Estimate against measurement, compound 3: 1.2-fold (0.08 log units) below, and the stated range covers the measured number.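

In this assay, nitro in place of fluoro on an aromatic carbon gives a 1.4-fold higher number from compound 1 to compound 3 (0.16 log units; within the scatter), so these two groups cannot be told apart at this ring carbon. With compound 3, a six-membered aromatic ring of carbon only on the saturated chain carbon has now given a number twice, while compound 2, with thiophen-2-yl at that place, goes against this with only "not active", and the size of that gap cannot be read. Nothing shown offers a reason for either result.

With compound 2 as the only five-membered ring, the compounds do not separate ring size from the sulfur atom, so furan-2-yl or an unsubstituted phenyl at this place would be informative. From the compounds shown here alone, how an amine or a carboxylic acid on that aromatic carbon would read also remains open.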